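Enone for ester on the seven-membered ring: compound 4

The source may hold more compounds than are shown below. What is called first, only, known or untested is meant among the compounds shown, and "the series" means these compounds.

Compound 1 `COC(=O)CC1=CC[C@H]2[C@H](C[C@@H]1C)OC(=O)[C@H]2C` sits at the limit of a functional assay on BV-2 cells (Mus musculus, strain C57BL6/J) for inhibition, read by Griess assay, with a stated time of 24 h (a lower number here means a stronger inhibitor, a higher number a weaker inhibitor), giving only > 10000 nM, which is a limit and not a number. Compound 2 `C[C@H]1C[C@@H]2OC(=O)[C@H](C)[C@H]2C=CC1=O` also gives a limit in this assay, > 10000 nM. Compound 3 `COc1cc([C@@H]2Oc3c(OC)cc(C(=O)[C@H](O)CO)cc3[C@H]2CO)ccc1O` likewise returns a limit, > 10000 nM. Among the compounds with values here, every value so far is a limit: the limit of > 10000 nM in this assay, at which 3 of the 3 values shown sit. Compound 4 `CC(=O)/C=C/C1=CC[C@H]2[C@H](C[C@@H]1C)OC(=O)[C@H]2C` has not been measured in this assay; it differs from compound 1 by 2-acetylethenyl in place of (methoxycarbonyl)methyl on a double-bonded ring carbon. Within the data shown here, no measured step is available, so the change is judged from the limits alone. Compound 4 is expected to remain near the limit, with an estimated step of an at least 1.1-fold lower number from compound 1 to compound 4 (0.04 log units; that floor lies within the scatter), not clearly beyond the scatter in either direction. The estimate for compound 4 is 9000 nM, within 2500 nM to 30000 nM.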

Compound 4, half-maximal inhibitory concentration: > 10000 nM
Compound 4 was reported as a limit; the forecaster's own chance of this, stated with the estimate: 65%; middle value at least 1.1-fold (0.04 log units) from the limit.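

Within the data shown here, compound 1 and compound 4 both stand at a limit, so no step between them can be read. Whether any change to the core of compound 1 gives a measurable value stays open: the limit of > 10000 nM in this assay, at which 4 of the 4 values shown sit.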